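A few compounds are considered here, and "the series" means these few. Any claim that something is new, unique, unknown or untested is made for them only; others in the source may bear on it.

- Compound 1 `COc1ccc(-c2ncnn2-c2cc(OC)c(OC)c(OC)c2)cc1`: 50 nM
- Compound 2 `COc1cccc(-c2ncnn2-c2cc(OC)c(OC)c(OC)c2)c1`: > 10000 nM, a limit of the assay
- Compound 3 `CCOc1ccc(-c2ncnn2-c2cc(OC)c(OC)c(OC)c2)cc1`: 5 nM

These values come from a functional assay on Jurkat cells (Homo sapiens) for antiproliferative activity, read by MTT assay, with a stated time of 72 h; a higher number here means a weaker inhibitor, a lower number a stronger inhibitor. Compound 3 stands at 5 nM, the lowest of the actual numbers, with compound 1 nearest at 50 nM. Compound 4 `COc1cc(-n2ncnc2-c2ccccc2)cc(OC)c1OC` has hydrogen in place of ethoxy on an aromatic carbon, para to a large group (hydrogen in place of ethoxy on an aromatic carbon).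

Within the data shown here, two measured steps bear on this change. The modest step of a 10-fold lower number from compound 1 to compound 3 (1.00 log units; beyond the scatter) adds methyl to the chain of the alkoxy group. The large step of an at least 200-fold higher number from compound 1 to compound 2 (2.30 log units; beyond the scatter) has 3-methoxyphenyl in place of 4-methoxyphenyl. The value of compound 2 is only a limit. Like compound 2, compound 4 carries no alkoxy group para to a large group, so a large rise is expected rather than a modest one, given an at least 200-fold higher number from compound 1 to compound 2 (2.30 log units; beyond the scatter). The expected change is a 600-fold higher number from compound 3 to compound 4 (2.78 log units; beyond the scatter). Among the measured compounds shown here, no measured compound has plain hydrogen there, so this estimate is uncertain. For compound 4 the estimated value is 3000 nM, with an expected range from 300 nM to 10000 nM.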

Compound 4, half-maximal inhibitory concentration: > 10000 nM
Compound 4: a limit, no number (the forecaster's own chance of this, stated with the estimate: 35%); middle value at least 3.3-fold (0.52 log units) away from the limit.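

In this assay compound 4 gives > 10000 nM, which is a limit of the assay. With hydrogen in place of ethoxy, the result is an at least 2000-fold higher number from compound 3 to compound 4 (3.30 log units; beyond the scatter), and with hydrogen in place of methoxy, it is an at least 200-fold higher number from compound 1 to compound 4 (2.30 log units; beyond the scatter), so among the compounds shown, only those with an alkoxy group on this aromatic carbon, para to a large group, give a number rather than a limit. The step between compound 2 and compound 4 cannot be read, since both sit at the same limit: the limit of > 10000 nM in this assay, at which 2 of the 4 values shown sit.

The compounds shown leave open how far the activity of compound 4 lies past that limit. They also leave open whether a longer chain such as propoxy would lower the number further, and whether an amine or a methyl group on this carbon could take the place of the alkoxy group.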